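The compounds below may be only part of what the source reports. "The series", "measured", "known", "first", "only" and "open" are said of these compounds alone.

Compound 1, `CC1=CC[C@H](C(C)(C)NC(=S)NN)CC1`, gives 39300 nM in a functional assay on NCI/ADR-RES cells (Homo sapiens) for inhibition, read by sulforhodamine B assay, with a stated time of 48 h; a higher number here means a weaker inhibitor of growth, a lower number a stronger inhibitor of growth.
Compound 2, `CC1=CC[C@H](C(C)(C)NC(=S)N/N=C/c2ccc(Cl)cc2)CC1`, gives 65200 nM in this assay.
Compound 3, `CC1=CC[C@H](C(C)(C)NC(=S)N/N=C/c2ccc[nH]2)CC1`, gives 78000 nM in this assay.

All three share one core and differ only at the far nitrogen. Two steps are known: a 2.0-fold higher number from compound 1 to compound 3 (0.30 log units; within the scatter); and a 1.2-fold higher number from compound 2 to compound 3 (0.08 log units; within the scatter). Compound 3 therefore sits within the usual scatter of both other compounds. Compound 4, `CC1=CC[C@H](C(C)(C)NC(=S)N/N=C/c2cccs2)CC1`, alters compound 3 by thiophen-2-yl in place of 1H-pyrrol-2-yl on a carbon with a double bond to nitrogen. The closest guide is the ring swap at that same carbon, which stayed within scatter, as did the step that added the whole ring. For compound 4 no step beyond the scatter is expected in this assay, a 1.1-fold lower number from compound 3 to compound 4 (0.05 log units; within the scatter). Compound 4 is estimated at 70000 nM, with a range from 35000 nM to 140000 nM.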

Compound 4, concentration for 50% growth inhibition: 13600 nM
Beside the measured number, compound 4's estimate is 5.1-fold (0.71 log units) above it; the measured number lies below the stated range.
By their numbers in this assay, from the lowest: compound 4; then compounds 1, 2 and 3 (each within the scatter of the next).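

In this assay, among these compounds, the ring at the carbon with a double bond to nitrogen turns out to matter: thiophen-2-yl in place of 1H-pyrrol-2-yl gives the first step beyond the scatter in this set (a 5.7-fold lower number from compound 3 to compound 4 (0.76 log units; beyond the scatter)). The thiophen-2-yl ring also clears the scatter against 4-chlorophenyl (a 4.8-fold lower number from compound 2 to compound 4 (0.68 log units; beyond the scatter)) and against the end without a ring (a 2.9-fold lower number from compound 1 to compound 4 (0.46 log units; beyond the scatter)).

The compounds shown leave open how furan-2-yl or plain phenyl would behave at this carbon. Nothing available explains why thiophen-2-yl and 1H-pyrrol-2-yl differ here.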